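Methyl to ethyl on a pyrazole in an A2780 cell assay

The source may hold more compounds than are shown below. What is called first, only, known or untested is meant among the compounds shown, and "the series" means these compounds.

Of the compounds shown here, three sharing one core have been tested in a functional assay on A2780 cells (Homo sapiens) for inhibition; a lower number here means a stronger inhibitor, a higher number a weaker inhibitor. Compound 1 `CCNC(=O)c1noc(-c2cc(C(C)C)c(O)cc2O)c1-c1ccn(CC)n1` gives 13 nM. Compound 2 `CCNC(=O)c1noc(-c2cc(C(C)C)c(O)cc2O)c1-c1ccn(C(C)C)n1` gives 45 nM, and compound 3 `CCNC(=O)c1noc(-c2cc(C(C)C)c(O)cc2O)c1-c1cnn(C)c1` gives 20 nM. From compound 1 to compound 2 the change is methyl in place of hydrogen on a saturated chain carbon bound to an aromatic nitrogen and a saturated chain carbon, and it brought a 3.5-fold higher number from compound 1 to compound 2 (0.54 log units; beyond the scatter). The two cores differ in this way: 1-methyl-1H-pyrazol-4-yl in place of 1-ethyl-1H-pyrazol-3-yl on an aromatic carbon, a change that gave a 1.5-fold higher number from compound 1 to compound 3 (0.19 log units; within the scatter), so compound 1 and compound 3 cannot be ordered against each other here.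

Compound 4 `CCNC(=O)c1noc(-c2cc(C(C)C)c(O)cc2O)c1-c1cnn(CC)c1` has not yet been measured. It differs from compound 3 thus: methyl in place of hydrogen on a saturated chain carbon bound to an aromatic nitrogen. Among the compounds with values here, this is the same kind of change as the one from compound 1 to compound 2, though not the same: there the carbon that gains the methyl is bound to an aromatic nitrogen and a saturated chain carbon, here only to an aromatic nitrogen, so the chain grows from methyl to ethyl rather than from ethyl to isopropyl. Because the earlier change brought a 3.5-fold higher number from compound 1 to compound 2 (0.54 log units; beyond the scatter), a weakening is expected for compound 4 too, though a shorter chain grows here; the estimated step is a 1.6-fold higher number from compound 3 to compound 4 (0.20 log units; within the scatter). Compound 4 is therefore expected to give about 32 nM in this assay, most likely between 13 nM and 80 nM.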

Compound 4, half-maximal inhibitory concentration: 30 nM
Beside the measured number, compound 4's estimate is 1.1-fold (0.03 log units) above it, within the range that was stated.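

In this assay, the methyl addition on the second core gave a 1.5-fold higher number from compound 3 to compound 4 (0.18 log units; within the scatter), whereas on the first core its step lies beyond the scatter, yet the two steps cannot be told apart: the same change on two cores in this assay, a 3.5-fold higher number (0.54 log units; beyond the scatter) from compound 1 to compound 2 and a 1.5-fold higher number (0.18 log units; within the scatter) from compound 3 to compound 4, 2.3-fold (0.36 log units) apart, within the scatter of two such steps. This shows that the change can be carried from one core to the other with no detectable difference in its size, but two pairs cannot prove that its size is the same, or that growing ethyl to isopropyl costs more than growing methyl to ethyl. Replacing 1-ethyl-1H-pyrazol-3-yl with 1-ethyl-1H-pyrazol-4-yl gave a 2.3-fold higher number from compound 1 to compound 4 (0.36 log units; beyond the scatter), a modest step, while replacing 1-isopropyl-1H-pyrazol-3-yl with 1-ethyl-1H-pyrazol-4-yl gave a 1.5-fold lower number from compound 2 to compound 4 (0.18 log units; within the scatter), which leaves that pair unordered.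

The compounds shown leave open how 1-methyl-1H-pyrazol-3-yl would compare, which would give a third pair for the same methyl addition. They also leave open what a longer chain such as propyl, or a cyclopropyl group, would do in place of the ethyl.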